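A few compounds are considered here, and "the series" means these few. Any claim that something is new, unique, unknown or untested is made for them only; others in the source may bear on it.

The study concerns four compounds that share one core and differ only in the group on a double-bonded ring carbon. Compound 1 `O=C1C(NC2CC2)=CC(=O)c2c1nc1n2[C@H]2OC[C@@H](O)[C@H]2OC1` carries a cyclopropylamino group, compound 2 `CCOc1ccccc1NC1=CC(=O)c2c(nc3n2[C@H]2OC[C@@H](O)[C@H]2OC3)C1=O` a 2-ethoxyphenylamino group, compound 3 `O=C1C(N2CCCC2)=CC(=O)c2c1nc1n2[C@H]2OC[C@@H](O)[C@H]2OC1` a pyrrolidin-1-yl group, and compound 4 `O=C1C(Nc2ccc(Br)cc2)=CC(=O)c2c1nc1n2[C@H]2OC[C@@H](O)[C@H]2OC1` a (4-bromophenyl)amino group. In a functional assay on MGC-803 cells (Homo sapiens) for inhibition, read by sulforhodamine B assay (on this read-out lower numbers stand for stronger inhibition and higher numbers for weaker inhibition), compound 2 gives 2830 nM. Compound 1 reaches only a limit of the assay, > 4000 nM. Compound 3 likewise reaches only a limit, > 16000 nM; on the numbers shown it stands at one of the two limits, with no number of its own. The change to compound 4 is (4-bromophenyl)amino in place of pyrrolidin-1-yl on a double-bonded ring carbon. Within the data shown here, two measured steps bear on it. The step of an at least 1.4-fold lower number from compound 1 to compound 2 (0.15 log units; that floor lies within the scatter) puts 2-ethoxyphenyl in place of cyclopropyl on an amine nitrogen; the step that the two limits leave unreadable from compound 1 to compound 3 is unreadable because the limit of > 4000 nM in this assay, at which 1 of the 3 values shown sits, and the limit of > 16000 nM in this assay, at which 1 of the 3 values shown sits, are its two ends. Among the measured compounds shown here, compound 2 is the only compound with an arylamino group that has a number, so the expectation for compound 4 rests on it: a step of an at least 6.4-fold lower number from compound 3 to compound 4 (0.80 log units; beyond the scatter) is expected, toward stronger inhibition. Compound 4 is therefore estimated at 2500 nM, with a range from 800 nM to 8000 nM.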

Compound 4, half-maximal inhibitory concentration: 2020 nM
Compound 4: the middle estimate sits 1.2-fold (0.09 log units) above what was measured, and the stated range covers the measured number.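

In this assay, the swap of pyrrolidin-1-yl for (4-bromophenyl)amino on the double-bonded ring carbon gives the first step at this position that is readable beyond the scatter, an at least 7.9-fold lower number from compound 3 to compound 4 (0.89 log units; beyond the scatter), although its size is only a floor, with one end at a limit: the limit of > 16000 nM in this assay, at which 1 of the 4 values shown sits.

Between the two arylamino groups the step is a 1.4-fold lower number from compound 2 to compound 4 (0.15 log units; within the scatter), so 4-bromophenyl and 2-ethoxyphenyl on the amine nitrogen cannot be told apart in this assay, and a second, differently substituted aromatic ring leaves the reading in the same range.

Against cyclopropyl on the amine nitrogen nothing firm follows, as the step is an at least 1.9-fold lower number from compound 1 to compound 4 (0.29 log units; that floor lies within the scatter), and this too is only a floor, with one end at a limit: the limit of > 4000 nM in this assay, at which 1 of the 4 values shown sits.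

The compounds shown do not separate the aromatic ring from the amine hydrogen, since compound 3 lacks both and compound 1 keeps the hydrogen yet stands at a limit. Going by these compounds, it also stays open how a methyl group on the amine nitrogen of compound 4, a benzylamino group or a morpholine ring would read at this double-bonded ring carbon.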